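From phenyl to 4-methoxyphenyl: an estimate for compound 4

The compounds below may be only part of what the source reports. "The series", "measured", "known", "first", "only" and "open" are said of these compounds alone.

Measured in a functional assay on K562 cells (Homo sapiens) for inhibition, read by sulforhodamine B assay, with a stated time of 48 h (on this read-out lower numbers stand for stronger inhibition of growth and higher numbers for weaker inhibition of growth), the compounds read as follows
Compound 1 `COc1ccc(-c2c(CNC(C)(C)C)c(C(=O)O)nn2-c2ccccc2)cc1` gives > 659000 nM as a limit
Compound 2 `CC(C)(C)NCc1c(C(=O)O)nn(-c2ccc(Cl)cc2)c1-c1ccc(Br)cc1` gives 297000 nM as a number
Compound 3 `CC(C)(C)NCc1c(C(=O)O)nn(-c2ccc(Cl)cc2)c1-c1ccccc1` gives > 652000 nM as a limit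

Compound 3 thus stands at a limit, > 652000 nM in this assay being no number. The next compound is compound 4 `COc1ccc(-c2c(CNC(C)(C)C)c(C(=O)O)nn2-c2ccc(Cl)cc2)cc1` and the change to it is methoxy in place of hydrogen on an aromatic carbon with methoxy in place of hydrogen on an aromatic carbon. Within the data shown here, one measured step bears on this, an at least 2.1-fold higher number from compound 2 to compound 3 (0.34 log units; beyond the scatter) and it too alters a single group on an aromatic carbon. Compound 1 already carries 4-methoxyphenyl, and its > 659000 nM is again a limit. On the evidence of an at least 2.1-fold higher number from compound 2 to compound 3 (0.34 log units; beyond the scatter) a modest fall in the number is expected in this assay with no more than that size, and possibly nothing beyond the scatter. The expected change is an at least 1.4-fold lower number from compound 3 to compound 4 (0.16 log units; that floor lies within the scatter) as an estimate only. For compound 4 the estimated value is 450000 nM with an expected range from 200000 nM to 800000 nM in this read-out.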

Compound 4, concentration for 50% growth inhibition: > 605000 nM
Compound 4 ended at the assay's limit (the forecaster's own chance of this, stated with the estimate: 50%); at least 1.3-fold (0.12 log units) between middle value and limit.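

In this assay compound 4 gives > 605000 nM, which is a limit of the assay and not a number, so 4-methoxyphenyl gives no number here with the chloro-bearing ring on the shared core, just as it gave none in compound 1. Bromo replaced by methoxy reads an at least 2.0-fold higher number from compound 2 to compound 4 (0.30 log units; that floor lies within the scatter), so this step alone does not separate the two groups, and compound 2 remains the only one of the four with a number. The steps reaching compound 4 from compound 3 and from compound 1 have limits at both ends and cannot be read.

On these data alone, how far compounds 1, 3 and 4 lie past their limits remains open. So does how an amine, a nitrile or a chloro group at this same place on the ring would read.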